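From Benzoyl to (tert-Butyl)carbonyl on the Amide

The compounds below may be only part of what the source reports. "The series", "measured", "known", "first", "only" and "open" are said of these compounds alone.

Measured in a functional assay on CCRF-CEM cells (Homo sapiens) for inhibition; on this read-out lower numbers stand for stronger inhibition and higher numbers for weaker inhibition:
compound 1 `Cn1cc(C#N)c2ccc(Nc3ncc(-c4ccccc4CN)o3)cc21`: 1100 nM
compound 2 `Cn1cc(C#N)c2ccc(Nc3ncc(-c4ccc(CN)cc4)o3)cc21`: 2800 nM
compound 3 `Cn1cc(C#N)c2ccc(Nc3ncc(-c4ccc(CNC(=O)c5ccccc5)cc4)o3)cc21`: > 10000 nM (a limit of the assay)

Compound 3 gives > 10000 nM, which is a limit and not a number. The next compound, compound 4 `Cn1cc(C#N)c2ccc(Nc3ncc(-c4ccc(CNC(=O)C(C)(C)C)cc4)o3)cc21`, differs from it in one place, with tert-butyl in place of phenyl on a carbonyl carbon.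

For the measured compounds named here, no measured step makes this exact swap. The closest guide is an at least 3.5-fold higher number from compound 2 to compound 3 (0.55 log units; beyond the scatter), where benzoyl took the place of hydrogen on an amine nitrogen. Compound 4 keeps a carbonyl on that nitrogen, so it is expected to stay weak, as that step suggests. The other step, a 2.5-fold higher number from compound 1 to compound 2 (0.41 log units; beyond the scatter), concerns the aminomethyl group and bears little on this change.

In this assay the expected step is an at least 1.2-fold lower number from compound 3 to compound 4 (0.09 log units; that floor lies within the scatter), which would be no clear change beyond the scatter. Compound 4 is estimated at 8000 nM, with an expected range of 3000 nM to 25000 nM.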

Compound 4, half-maximal inhibitory concentration: 4900 nM
Beside the measured number, compound 4's estimate is 1.6-fold (0.21 log units) above it; measured number inside the range.
By their numbers in this assay, from the lowest: compound 1; then compounds 2 and 4 (each within the scatter of the next). At a limit, above all of these: compound 3.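

Compound 3 stands at a limit of the assay and not at a number: the limit of > 10000 nM in this assay, at which 1 of the 4 values shown sits. Against that limit, tert-butyl in place of phenyl on the carbonyl carbon gives an at least 2.0-fold lower number from compound 3 to compound 4 (0.30 log units; that floor lies within the scatter), so in this assay a carbonyl on the amine nitrogen does not by itself push a compound to the limit, although this floor alone shows no clear change. The second step, a 1.8-fold higher number from compound 2 to compound 4 (0.24 log units; within the scatter), shows that (tert-butyl)carbonyl on that nitrogen leaves the number indistinguishable from that of the free amine.

A cyclohexyl group on the same carbonyl carbon would help to tell whether the ring's aromatic character or its mere presence matters, and an acetyl group would test a much smaller amide. On these data alone, how a (tert-butyl)carbonyl amide would behave on the 2-(aminomethyl)phenyl group of compound 1 also remains open.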